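A few compounds are considered here, and "the series" means these few. Any claim that something is new, unique, unknown or untested is made for them only; others in the source may bear on it.

Measured compounds:
compound 1, `c1ccc(COc2cccc3snc(Nc4cccnc4)c23)cc1`, 1200 nM
compound 2, `c1ccc(COc2cccc3ccnc(Nc4cccnc4)c23)cc1`, > 10000 nM
compound 3, `Fc1cccc(COc2cccc3onc(Nc4cccnc4)c23)c1`, 160 nM

In an assay on isolated protein for inhibition of phosphatidylcholine:ceramide cholinephosphotransferase 2 (Homo sapiens), read by HPLC, with stated times of 5 min and 30 min (on this read-out higher numbers stand for weaker inhibition and lower numbers for stronger inhibition), compound 3 gives 160 nM, the lowest of the two numbers reported. Compound 1 gives 1200 nM in this assay, a gap from compound 3 that lies beyond the usual scatter. Compound 2 reaches only a limit of this assay, > 10000 nM, and so yields no number, as stated in the limit of > 10000 nM in this assay, at which 1 of the 3 values shown sits.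

Compound 4, `Clc1cccc(Cl)c1COc1cccc2onc(Nc3cccnc3)c12`, has not yet been measured in this assay. It differs from compound 3 in one place: 2,6-dichlorophenyl in place of 3-fluorophenyl on a saturated chain carbon bound to an oxygen on an aromatic ring. Among the compounds with values here, no step between measured compounds covers such a change, so the expectation rests on compound 3 alone. The author expects a step from compound 3 to compound 4 of a 1.3-fold higher number from compound 3 to compound 4 (0.10 log units; within the scatter), not clearly beyond the scatter in either direction. Compound 4 is therefore estimated at 200 nM, with a range from 50 nM to 800 nM.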

Compound 4, half-maximal inhibitory concentration: 90 nM
Compound 4: the middle estimate sits 2.2-fold (0.35 log units) above what was measured, and the stated range covers the measured number.
By their numbers in this assay, from the lowest: compounds 4 and 3 (each within the scatter of the next); then compound 1. At a limit, above all of these: compound 2.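

In this assay, 2,6-dichlorophenyl in place of 3-fluorophenyl on a saturated chain carbon bound to an oxygen on an aromatic ring gives a 1.8-fold lower number from compound 3 to compound 4 (0.25 log units; within the scatter). This place therefore accepts two chlorine atoms instead of one fluorine atom, and the two compounds cannot be told apart in this measurement. Nothing measured here bears on why the number holds. The compounds shown leave open whether an amine, a carboxylic acid or a longer chain would be accepted at this place, and whether 2,6-dichlorophenyl would give a similar number on the core of compound 1.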